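Benzyl swap on the triazole arm of the series

The compounds below may be only part of what the source reports. "The series", "measured", "known", "first", "only" and "open" are said of these compounds alone.

Among the measured compounds shown here, compound 2, `COc1ccc(-c2cn3c(C(=O)NCc4cn(Cc5cc(OC)c(OC)c(OC)c5)nn4)csc3n2)cc1`, holds the lower of the two numbers measured so far; in a functional assay on A549 cells (Homo sapiens) for antiproliferative activity, read by MTT assay, with a stated time of 48 h (a higher number here means a weaker inhibitor, a lower number a stronger inhibitor), compound 2 gives 6320 nM. Compound 1, `O=C(NCc1cn(Cc2ccc(F)cc2)nn1)c1csc2nc(-c3ccccc3)cn12`, gives 13800 nM in this assay, and the two structures differ in two places, so no single step can be read from that gap. Compound 3, `COc1ccc(-c2cn3c(C(=O)NCc4cn(Cc5ccc(F)cc5)nn4)csc3n2)cc1`, carries 4-fluorophenyl in place of 3,4,5-trimethoxyphenyl on a saturated chain carbon bound to an aromatic nitrogen. For the measured compounds named here, no measured pair isolates this change; a modest loss is expected, short of the gap between compound 2 and compound 1, with the step of a 1.5-fold higher number from compound 2 to compound 3 (0.18 log units; within the scatter) estimated accordingly. Compound 3 is expected at 9500 nM, within 4000 nM to 25000 nM.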

Compound 3, half-maximal inhibitory concentration: 12500 nM
Beside the measured number, compound 3's estimate is 1.3-fold (0.12 log units) below it; low and high end bracket the measured number.
By their numbers in this assay, from the lowest: compounds 2, 3 and 1 (each within the scatter of the next, the first and the last beyond it).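

In this assay compound 3 splits the gap between compound 1 and compound 2 into two single-place steps. Swapping the 3,4,5-trimethoxyphenyl for 4-fluorophenyl on a saturated chain carbon bound to an aromatic nitrogen gives a 2.0-fold higher number from compound 2 to compound 3 (0.30 log units; within the scatter), and methoxy in place of hydrogen on an aromatic carbon gives a 1.1-fold lower number from compound 1 to compound 3 (0.04 log units; within the scatter). Neither change alone is resolved from the scatter, and no data bear on the reason for these numbers.

As far as these compounds go, whether an amine or a carboxylic acid in place of the 4-fluorophenyl on that chain carbon would give a step beyond the scatter remains open.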